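Prenyloxy flavanone series: methoxy additions and inhibition

A few compounds are considered here, and "the series" means these few. Any claim that something is new, unique, unknown or untested is made for them only; others in the source may bear on it.

Measured compounds:
Compound 1, `CC(C)=CCOc1ccc2c(c1)OC(c1ccccc1)CC2=O`: in a functional assay (on this read-out higher numbers stand for weaker inhibition and lower numbers for stronger inhibition), compound 1 gives 6070 nM.
Compound 2, `COc1ccc(C2CC(=O)c3ccc(OCC=C(C)C)cc3O2)cc1`: in this assay compound 2 gives 10200 nM.
Compound 3, `COc1ccc(C2CC(=O)c3c(O)cc(OCC=C(C)C)cc3O2)cc1`: in this assay compound 3 gives 5080 nM.

The change methoxy in place of hydrogen on an aromatic carbon gives a 1.7-fold higher number from compound 1 to compound 2 (0.23 log units; within the scatter). The further change, hydroxy in place of hydrogen on an aromatic carbon, gives a 2.0-fold lower number from compound 2 to compound 3 (0.30 log units; within the scatter). All three values lie within the scatter of one another, so no ordering among them is read.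

Compound 4, `COc1ccc(C2CC(=O)c3c(O)cc(OCC=C(C)C)cc3O2)c(OC)c1`, is not yet measured. It differs from compound 3 by methoxy in place of hydrogen on an aromatic carbon. The difference between the core of compound 1 and the core of compound 3 is not broken down here. The change from compound 1 to compound 2 sits para to a large group, whereas the change from compound 3 to compound 4 sits ortho to a large group and meta to a methoxy group; it is the same kind of change, not the same.

In this assay the step of a 1.3-fold higher number from compound 3 to compound 4 (0.11 log units; within the scatter) is expected, set beside a 1.7-fold higher number from compound 1 to compound 2 (0.23 log units; within the scatter), on which this expectation rests; a step within the scatter is anticipated. Compound 4 is estimated at 6500 nM, within 2500 nM to 17000 nM.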

Compound 4, half-maximal inhibitory concentration: 2320 nM
Compound 4: the middle estimate sits 2.8-fold (0.45 log units) above what was measured; measured number below the stated range.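

In this assay, methoxy in place of hydrogen on an aromatic carbon gives a 2.2-fold lower number from compound 3 to compound 4 (0.34 log units; beyond the scatter), and this step does not match the one seen earlier on the core of compound 1: the same change on two cores in this assay, a 1.7-fold higher number (0.23 log units; within the scatter) from compound 1 to compound 2 and a 2.2-fold lower number (0.34 log units; beyond the scatter) from compound 3 to compound 4, 3.7-fold (0.57 log units) apart, beyond the scatter of two such steps

Among the compounds shown here, the result shows that the size and direction of this change cannot simply be carried from one core to the other, although the new step is modest and each core contributes only a single pair. It does not show what sets the two steps apart, since the cores differ and the new methoxy, ortho to a large group and meta to a methoxy group, does not stand where the earlier one stands, so core and place cannot be separated.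

Open, on these data alone, is whether methoxy at this same place on the core of compound 1 would give a step like the new one. Also open, as far as these compounds go, is whether a longer alkoxy chain or an amine at that place would follow methoxy.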